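A few compounds are considered here, and "the series" means these few. Any claim that something is new, unique, unknown or untested is made for them only; others in the source may bear on it.

Measured so far:
- compound 1 `CCN(c1ccc(C#N)c(Cl)c1)c1cc(-c2cccs2)ccc1C`: 22000 nM
- compound 2 `CCN(c1cccc(-n2ccnc2)c1)c1ccc(C#N)c(Cl)c1`: > 30000 nM
- compound 3 `N#Cc1ccc(N2CCc3cc(-c4cccnc4)ccc3C2)cc1C(F)(F)F`: 4790 nM

Of the compounds shown here, three have been tested in a functional assay on CWR22R cells (Homo sapiens) for antiproliferative activity, read by CCK-8 assay, with a stated time of 6 days; a lower number here means a stronger inhibitor, a higher number a weaker inhibitor. Compound 1 gives 22000 nM, the highest of the two plain numbers in this assay; the nearest neighbour is compound 3, whose number of 4790 nM is lower by a gap beyond the usual scatter. For compound 2 the assay reports no number, only the limit (the limit of > 30000 nM in this assay, at which 1 of the 3 values shown sits).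

Compound 4 `CCN(c1ccc(C#N)c(Cl)c1)c1cc(-n2cnc3ccccc32)ccc1C` has not yet been measured. It comes from compound 1 by one change: 1H-benzimidazol-1-yl in place of thiophen-2-yl on an aromatic carbon. Nothing measured here connects these two groups at this place, so the size of the step can only be guessed. The benzimidazolyl group brings a second ring where the thiophenyl group had one, and both compounds share the same core with the ethyl group on the nitrogen and the nitrile and chlorine in their places.

In this assay compound 4 is expected to give about 18000 nM, most likely between 5000 nM and 40000 nM. That expectation means a step of a 1.2-fold lower number from compound 1 to compound 4 (0.09 log units; within the scatter), not clearly beyond the scatter in either direction.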

Compound 4, half-maximal inhibitory concentration: 3040 nM
Compound 4: middle estimate off by 5.9-fold (0.77 log units), on the high side, and the stated range ends above it.
By their numbers in this assay, from the lowest: compounds 4 and 3 (each within the scatter of the next); then compound 1. At a limit, above all of these: compound 2.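

In this assay, among the compounds shown here, putting 1H-benzimidazol-1-yl in place of thiophen-2-yl gives a 7.2-fold lower number from compound 1 to compound 4 (0.86 log units; beyond the scatter), the first comparison in this set between two compounds that differ in only one place. For the compounds shown here, it shows that the group on this aromatic carbon, meta to a large group and para to a methyl group, can shift the antiproliferative number by a modest but real amount while the rest of the molecule stays the same, something the earlier compounds could not show on their own. The data shown give no measured property that accounts for this step.

The change swaps one ring for two and sulfur for nitrogen at the same time, so the compounds shown leave open which of these differences matters, and how far the number would move with other groups at this place. An indol-1-yl group, which keeps both rings of the benzimidazole but differs from it in the five-membered ring, or a simple phenyl group on the same core, would help to pull these differences apart.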